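The compounds below may be only part of what the source reports. "The series", "measured", "known", "first", "only" and "open" are said of these compounds alone.

Two close relatives of one core have been measured. Within the data shown here, compound 1 `C=C(Br)C(=O)Nc1cccc(-c2cn3nc(-c4ccc(CC)cc4)sc3n2)c1` gives 2200 nM in a functional assay on L1210 cells (Mus musculus) for inhibition, read by cell counting, with a stated time of 2 days (on this read-out higher numbers stand for weaker inhibition and lower numbers for stronger inhibition), and compound 2 `C=C(Br)C(=O)Nc1cccc(-c2cn3nc(-c4ccc(OCC)cc4)sc3n2)c1` gives 790 nM; the only step between them, a 2.8-fold lower number from compound 1 to compound 2 (0.44 log units; beyond the scatter), came with ethoxy in place of ethyl on an aromatic carbon. Among the measured compounds shown here, compound 2 therefore holds the lower of the two numbers so far. Compound 3 `C=C(Br)C(=O)Nc1cccc(-c2cn3nc(-c4ccc(C)cc4)sc3n2)c1` differs from compound 2 by methyl in place of ethoxy on an aromatic carbon. For the measured compounds named here, only that single step bears on this change, and it suggests losing the ethoxy costs some inhibition, so compound 3 is expected to move by a 2.3-fold higher number from compound 2 to compound 3 (0.36 log units; beyond the scatter), toward a weaker result. Compound 3 is estimated at 1800 nM, within 700 nM to 4500 nM.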

Compound 3, half-maximal inhibitory concentration: 920 nM
Estimate against measurement, compound 3: 2.0-fold (0.29 log units) above; measured number inside the range.
By their numbers in this assay, from the lowest: compounds 2 and 3 (each within the scatter of the next); then compound 1.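

Replacing ethoxy with methyl at this place, para to a large group, gives two numbers that cannot be told apart (a 1.2-fold higher number from compound 2 to compound 3 (0.07 log units; within the scatter)), so the ethoxy oxygen is not required to reach this level of inhibition. Methyl does differ clearly from ethyl (a 2.4-fold lower number from compound 1 to compound 3 (0.38 log units; beyond the scatter)), so among these three compounds the number does not simply follow chain length: ethyl, the middle length, gives the weakest inhibition. Nothing available explains this pattern. On these data alone, whether a longer chain such as butoxy, or an amine or a carboxylic acid, would fit at this place remains open.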